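A few compounds are considered here, and "the series" means these few. Any claim that something is new, unique, unknown or untested is made for them only; others in the source may bear on it.

Measured compounds in a functional assay on HeLa cells (Homo sapiens) for antiproliferative activity, read by MTT assay, with a stated time of 48 h; a lower number here means a stronger inhibitor, a higher number a weaker inhibitor:

Compound 1 `COc1ccc2c(/C=C/C(=O)c3cc(OC)c(OC)c(SC)c3)c[nH]c2c1` gives 131 nM.
Compound 2 `COc1ccc2c(/C=C(\C)C(=O)c3cc(OC)c(OC)c([Se]C)c3)cn(C)c2c1` gives 32 nM.
Compound 3 `COc1ccc2c(/C=C/C(=O)c3cc(OC)c(OC)c(SC)c3)cn(C)c2c1` gives 167 nM.

Compound 2 sits at the low end of the three numbers, and its gap to compound 1 and to compound 3 is beyond the scatter in both cases. The difference between the core of compound 2 and the core of compound 3 is not broken down here; the two differ in more than one place.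

Compounds 3 and 1 share a core and differ in one place, (hydrogen in place of methyl on an aromatic nitrogen). This change produced a 1.3-fold lower number from compound 3 to compound 1 (0.11 log units; within the scatter), so within this series the two compounds count as equal in this assay.

Compound 4 `COc1ccc2c(/C=C(\C)C(=O)c3cc(OC)c(OC)c([Se]C)c3)c[nH]c2c1` has not been measured. It is related to compound 2 by hydrogen in place of methyl on an aromatic nitrogen. The place of this change is the same, word for word, as the place of the change from compound 3 to compound 1, so the same change is applied on the core of compound 2 instead.

The expectation for compound 4 rests on compound 2 and on the step from compound 3 to compound 1 a 1.3-fold lower number from compound 3 to compound 1 (0.11 log units; within the scatter). Since that step stayed within the scatter, compound 4 is expected to move only little from compound 2, with an estimated step of a 1.2-fold lower number from compound 2 to compound 4 (0.07 log units; within the scatter). Compound 4 is therefore estimated at 27 nM in this assay, with a likely range from 12 nM to 60 nM.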

Compound 4, half-maximal inhibitory concentration: 21 nM
For compound 4 the middle estimate is 1.3-fold (0.11 log units) above the measured one; measured number inside the range.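

In this assay, hydrogen in place of methyl on an aromatic nitrogen gives a 1.5-fold lower number from compound 2 to compound 4 (0.18 log units; within the scatter), and the steps on the two cores agree: the same change on two cores in this assay, a 1.3-fold lower number (0.11 log units; within the scatter) from compound 3 to compound 1 and a 1.5-fold lower number (0.18 log units; within the scatter) from compound 2 to compound 4, 1.2-fold (0.08 log units) apart, within the scatter of two such steps

On these two cores, the methyl on the aromatic nitrogen can therefore be exchanged for hydrogen with no change that can be told from the scatter, and this null result carries from one core to the other. Two pairs are a narrow base, however: they show no measurable effect of the change in this cell assay, but they do not establish that the result would hold on other cores in the series, and they give no reason for it.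

As far as these compounds go, only methyl and hydrogen appear on that nitrogen, so the outcome with a longer chain such as ethyl, a benzyl group or an acetyl group remains open. Compound 2 and compound 3 also differ in more than one place, which leaves the separate contributions of the methylseleno group in place of methylthio and of the extra methyl on the linking chain unresolved.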